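Amide nitrogen change from compound 3 to compound 4

The source may report more compounds than this note shows. Statements on the series, on what has been measured and on what is new or still open speak of the compounds shown alone.

Compound 3 `COc1ccc2c(=O)c(/C=C/C(=O)NCc3ccc(C)cc3)coc2c1` carries a 4-methylbenzyl on the amide-type nitrogen. In a functional assay on L02 cells (Homo sapiens) for inhibition, read by MTT assay, with a stated time of 48 h (on this read-out higher numbers stand for weaker inhibition and lower numbers for stronger inhibition), compound 3 gives only a limit, > 200000 nM. Compound 1 `COc1cccc(NC(=O)/C=C/c2coc3cc(OC)ccc3c2=O)c1` in this assay likewise gives only a limit, > 200000 nM. Compound 2 `COc1ccc2c(=O)c(/C=C/C(=O)Nc3ccccc3OC)coc2c1` in this assay also gives only a limit, > 200000 nM. All three values sit at the limit of > 200000 nM in this assay, at which 3 of the 3 values shown sit, so compound 3 cannot be placed relative to the other two. The steps a step that the two limits leave unreadable from compound 1 to compound 3 and a step that the two limits leave unreadable from compound 2 to compound 3 are not readable, and a step that the two limits leave unreadable from compound 1 to compound 2 is not readable either.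

Compound 4 `CCOc1ccc(NC(=O)/C=C/c2coc3cc(OC)ccc3c2=O)cc1` differs from compound 3 by 4-ethoxyphenyl in place of 4-methylbenzyl on an amide-type nitrogen. Among the measured compounds shown here, no measured step gives a size that bears on this change; all three run between limits. The expectation for compound 4 rests only on compound 3 standing at the limit of > 200000 nM in this assay, at which 3 of the 3 values shown sit. The step that the limit leaves unreadable from compound 3 to compound 4 is expected to be none beyond the scatter, with a limit the most likely read-out. Compound 4 is therefore estimated at 250000 nM in this assay, between 80000 nM and 1000000 nM.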

Compound 4, half-maximal inhibitory concentration: > 200000 nM
Compound 4: a limit, no number; the forecaster's own chance of this, stated with the estimate: 85%; the middle value lies beyond the limit too.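

In this assay, among the compounds shown here, compound 4 gives only a limit, > 200000 nM, so no new step to it from compound 1, compound 2 or compound 3 can be read. The compounds shown leave open whether any group on the amide-type nitrogen gives a readable value in this assay: the limit of > 200000 nM in this assay, at which 4 of the 4 values shown sit.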